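This account rests on a few compounds, and the source may have more. Where it says the series, first, only, none or still open, it means among the compounds named here.

Three amides built on one shared core have been measured in an assay on CHO cells for agonist activity at Neuronal acetylcholine receptor; alpha3/alpha6/beta2/beta3 (Homo sapiens), read by FLIPR and calcium flux; on this read-out higher numbers stand for larger maximal responses and lower numbers for smaller maximal responses. Compound 1 `CCC(=O)N1CC2CC(C1)N2` gives 120%, and compound 2 `O=C([C@@H]1C[C@@H]1F)N1CC2CC(C1)N2` gives 120%; the step between them, no change at the digits printed from compound 1 to compound 2 (within the scatter), puts a 2-fluorocyclopropyl in place of ethyl on a carbonyl carbon. Compound 3 `C[C@@H]1C[C@@H]1C(=O)N1CC2CC(C1)N2` gives 87% and stands lowest of the three: the steps of a number 33 percentage points lower from compound 1 to compound 3 (beyond the scatter) and a number 33 percentage points lower from compound 2 to compound 3 (beyond the scatter) were both large drops.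

Compound 4 `C[C@H]1C[C@@H]1C(=O)N1CC2CC(C1)N2` has the same atoms and bonds as compound 3 and differs only in one drawn stereocentre: the two compounds have the same atoms and bonds; at least one stereo element is drawn with a configuration in one of them and without one in the other: 1 of 4 stereo elements differ; a stereocentre at a saturated ring carbon is drawn R in compound 3 and S in compound 4. Among the compounds with values here, none of the three measured steps turns a stereocentre alone, so no measured step shows how this assay answers such a change. The two large drops that led to compound 3 do show that the maximal response reacts strongly to the methylcyclopropyl part, so its mirror-drawn partner could sit anywhere from the level of compound 3 up to that of compound 1. The step of a number 13 percentage points higher from compound 3 to compound 4 (beyond the scatter) is therefore only a loose expectation. Compound 4 is estimated at 100%, with a range from 70% to 125%.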

Compound 4, largest response reached (Emax), in percent of the reference or control that the assay uses: 64%
Compound 4: middle estimate off by 36 percentage points, on the high side; the measured number lies below the stated range.
By their numbers in this assay, from the lowest: compound 4; then compound 3; then compounds 1 and 2 (each within the scatter of the next).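

At a saturated ring carbon of the 2-methylcyclopropyl group, changing only the drawn stereocentre gives a number 23 percentage points lower from compound 3 to compound 4 (beyond the scatter) in this assay, so the maximal response answers to drawn configuration alone, with no atom entering or leaving. Measured against the other two amides, 2-methylcyclopropyl in place of 2-fluorocyclopropyl gives a number 56 percentage points lower from compound 2 to compound 4 (beyond the scatter), and 2-methylcyclopropyl in place of ethyl gives a number 56 percentage points lower from compound 1 to compound 4 (beyond the scatter), so both forms of the 2-methylcyclopropyl amide lie beneath those two amides, each by its own distance. One caution applies to the stereo comparison: the fact that one of compounds 3 and 4 is drawn with a defined configuration and the other without, at the place where they differ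

The compounds shown leave open whether the 2-fluorocyclopropyl amide would respond in the same way if its own stereocentre were turned. As far as these compounds go, it also remains open how a 2-chlorocyclopropyl or 2-ethylcyclopropyl group on the carbonyl carbon would behave in this assay.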